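A fluoro in place of hydrogen on compound 3

A few compounds are considered here, and "the series" means these few. Any claim that something is new, unique, unknown or untested is made for them only; others in the source may bear on it.

Measured in a functional assay on PC-3 cells (Homo sapiens) for cytotoxicity, read by MTT assay, with a stated time of 72 h; a lower number here means a stronger inhibitor, a higher number a weaker inhibitor:
- compound 1 `CNC(=O)c1cc(Oc2ccc(C3=NNC(c4cccc(Br)c4)C3)cc2)ccn1`: 3540 nM
- compound 2 `CNC(=O)c1cc(Oc2ccc(C3=NNC(c4ccc([N+](=O)[O-])cc4)C3)cc2)ccn1`: > 50000 nM (a limit)
- compound 3 `CNC(=O)c1cc(Oc2ccc(C3=NNC(c4ccccc4)C3)cc2)ccn1`: 4520 nM

Only two of these results are numbers, and compound 3 lies within the scatter of compound 1, with a 1.3-fold higher number from compound 1 to compound 3 (0.11 log units; within the scatter). Compound 2 gives > 50000 nM, which is a limit of the assay.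

The next structure, compound 4 `CNC(=O)c1cc(Oc2ccc(C3=NNC(c4ccc(F)cc4)C3)cc2)ccn1`, differs from compound 3 as follows: fluoro in place of hydrogen on an aromatic carbon. This is phenyl to 4-fluorophenyl.

Within the data shown here, two measured steps bear on this change, both replacing a group on an aromatic carbon with hydrogen. The first is the bromo step already given, which stays within the scatter. The second is the nitro step, an at least 11-fold lower number from compound 2 to compound 3 (1.04 log units; beyond the scatter), which is large and rests on a limit. Fluoro is a halogen, as bromo is, so the bromo step is taken as the closer guide, although its bromo sits on 3-bromophenyl. The nitro step, on 4-nitrophenyl, leaves some risk towards higher numbers. No step beyond the scatter is therefore expected in this assay. The expected change is a 1.1-fold higher number from compound 3 to compound 4 (0.04 log units; within the scatter). Compound 4 is estimated at 5000 nM, with an expected range of 2200 nM to 13000 nM.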

Compound 4, half-maximal inhibitory concentration: 6770 nM
Compound 4: the middle estimate sits 1.4-fold (0.13 log units) below what was measured; measured number inside the range.
By their numbers in this assay, from the lowest: compounds 1, 3 and 4 (each within the scatter of the next). At a limit, above all of these: compound 2.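

In this assay, fluoro on an aromatic carbon para to a large group stays within the scatter of the unsubstituted phenyl compound, a 1.5-fold higher number from compound 3 to compound 4 (0.18 log units; within the scatter), and 4-fluorophenyl also stays within the scatter of 3-bromophenyl, a 1.9-fold higher number from compound 1 to compound 4 (0.28 log units; within the scatter), so hydrogen, bromo and fluoro on this aryl ring cannot be told apart in this assay. Among these compounds, the new result also gives the first measured number for a group at the place that carries nitro in the 4-nitrophenyl compound, and the step between the two lies beyond the scatter, an at least 7.3-fold lower number from compound 2 to compound 4 (0.86 log units; beyond the scatter), which shows that a group at this place need not bring the loss seen with nitro. Compound 2 carries a limit and not a number, so the size of that step stays open: the limit of > 50000 nM in this assay, at which 1 of the 4 values shown sits.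

The compounds shown leave open whether the halogen or its place matters, since 3-bromophenyl and 4-fluorophenyl differ in both. They also leave open how an amine, a carboxylic acid or a methoxy group at this place would compare with fluoro and nitro.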